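This account rests on a few compounds, and the source may have more. Where it says the series, first, only, none or still open, it means among the compounds named here.

In a functional assay on NCI-H322M cells (Homo sapiens) for cytotoxicity, read by sulforhodamine B assay, with a stated time of 48 h, tested at 0.001 uM (on this read-out higher numbers stand for a weaker effect at the one concentration tested and lower numbers for a stronger effect), three compounds have been measured:

compound 1 `COc1cc(C)cc(-c2c(-c3ccnc(-c4ccc(C(C)=O)cc4)c3)cnn2CC#N)c1` — 102%
compound 2 `COc1cc(C)cc(-c2nn(CC#N)cc2-c2ccc(-c3cccc(C(C)=O)c3)nc2)c1` — 94%
compound 3 `Cc1cc(O)cc(-c2nn(CC#N)cc2-c2ccnc(-c3ccc(Oc4ccccc4)cc3)c2)c1` — 94%

Compound 1 carries the highest of the three numbers in this assay, but the gap to compound 2, the nearest, and to compound 3, the furthest, is the same in both cases and lies within the usual scatter, so the three compounds cannot be told apart on this read-out. All three sit close to the value that means no measurable effect at the single concentration tested.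

Compound 4 `COc1cc(C)cc(-c2c(-c3ccnc(-c4ccc(N(C)C)cc4)c3)cnn2CC#N)c1` has not yet been measured in this assay. It differs from compound 1 in one place: dimethylamino in place of acetyl on an aromatic carbon

Among the compounds with values here, with no measured pair showing the effect of such a change, and with all three measured compounds giving numbers near the no-effect level in this assay, no step beyond the scatter is expected for compound 4, and the change from compound 1 is estimated at a number 2 percentage points lower from compound 1 to compound 4 (within the scatter). Compound 4 is therefore expected to give about 100%, within a range from 88% to 112%.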

Compound 4, a percentage reported as activity, at one concentration (the size of the read-out at that concentration, not a potency): 97%
Beside the measured number, compound 4's estimate is 3 percentage points above it; the range from low to high includes it.
By their numbers in this assay, from the lowest: compounds 2, 3, 4 and 1 (each within the scatter of the next).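

At the aromatic carbon para to a large group, dimethylamino in place of acetyl now has a measured step in this assay and it reads a number 5 percentage points lower from compound 1 to compound 4 (within the scatter) at the one concentration tested. Within the data shown here, the exchange of 4-acetylphenyl for 4-(dimethylamino)phenyl thus leaves compound 4 near the no-effect level, where the earlier compounds also stood, so this position shows no response to this change at that concentration. No accompanying measurement bears on this result.

From the compounds shown here alone, whether a carboxylic acid, a primary amine or a longer chain on the same aromatic carbon would also stay within the scatter remains open. Also open, going by these compounds, is whether acetyl and dimethylamino would separate at any concentration other than the single one tested here.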